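A few compounds are considered here, and "the series" means these few. Any claim that something is new, unique, unknown or untested is made for them only; others in the source may bear on it.

Measured compounds in a functional assay on DLA cells (Mus musculus) for cytotoxicity, read by trypan blue exclusion, with a stated time of 48 h; on this read-out higher numbers stand for weaker inhibition and lower numbers for stronger inhibition:
Compound 1 `Cc1cc(C(=O)c2ccccc2)ccc1OCC(=O)Nc1nc(-c2ccccc2)cs1` gives 21500 nM.
Compound 2 `COc1ccc(-c2csc(NC(=O)COc3ccc(C(=O)c4ccccc4)cc3C)n2)cc1` gives 24200 nM.
Compound 3 `Cc1cc(C(=O)c2ccc(F)cc2)ccc1OCC(=O)Nc1nc(-c2ccccc2)cs1` gives 32100 nM.

Compound 4 `COc1ccc(-c2csc(NC(=O)COc3ccc(C(=O)c4ccc(F)cc4)cc3C)n2)cc1` has not yet been measured in this assay. It differs from compound 3 in one place: methoxy in place of hydrogen on an aromatic carbon. The same change has already been made once among these compounds, from compound 1 to compound 2, where it gave a 1.1-fold higher number from compound 1 to compound 2 (0.05 log units; within the scatter). The two cores on which this change sits differ in the way described by fluoro in place of hydrogen on an aromatic carbon, a change that gave a 1.5-fold higher number from compound 1 to compound 3 (0.17 log units; within the scatter). Since the place of the change is the same in both pairs, the change is taken as the same, and the step is expected to repeat, so that a 1.1-fold higher number from compound 3 to compound 4 (0.04 log units; within the scatter) is expected, resting on a 1.1-fold higher number from compound 1 to compound 2 (0.05 log units; within the scatter). For compound 4 the estimated value is 35000 nM, expected to fall between 17000 nM and 70000 nM.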

Compound 4, half-maximal inhibitory concentration: 5000 nM
Compound 4: the middle estimate sits 7.0-fold (0.85 log units) above what was measured; measured number outside the range, below it.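

In this assay, methoxy in place of hydrogen on the core of compound 3 gave a 6.4-fold lower number from compound 3 to compound 4 (0.81 log units; beyond the scatter), and this step does not match the one on the core of compound 1: the same change on two cores in this assay, a 1.1-fold higher number (0.05 log units; within the scatter) from compound 1 to compound 2 and a 6.4-fold lower number (0.81 log units; beyond the scatter) from compound 3 to compound 4, 7.2-fold (0.86 log units) apart, beyond the scatter of two such steps. Read the other way, fluoro in place of hydrogen gave a 4.8-fold lower number from compound 2 to compound 4 (0.68 log units; beyond the scatter), and that change does not carry over between cores either: the same change on two cores in this assay, a 1.5-fold higher number (0.17 log units; within the scatter) from compound 1 to compound 3 and a 4.8-fold lower number (0.68 log units; beyond the scatter) from compound 2 to compound 4, 7.2-fold (0.86 log units) apart, beyond the scatter of two such steps. The methoxy and fluoro steps therefore do not simply add in this series, but this rests on a single set of four compounds and does not show why the steps differ.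

Going by these compounds, it remains open whether the lower number of compound 4 depends on methoxy and fluoro specifically. On these data alone, whether an ethoxy or an amine in place of the methoxy, or a chloro in place of the fluoro, would give the same result also remains open.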